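The compounds below may be only part of what the source reports. "The series", "measured", "known", "first", "only" and "open" are said of these compounds alone.

Measured compounds:
compound 1 `COc1ccc(N(C(=O)CN2C=CN(c3ccccc3)C(=O)[C@@H](Cc3n[nH]c4ccccc34)C2=O)C(C)C)cc1`, 1550 nM in a functional assay on CHO cells for agonist activity at Melanocyte-stimulating hormone receptor (Homo sapiens), read by a luciferase reporter, with a stated time of 4 h; a higher number here means that more compound is needed for the effect, a lower number that less compound is needed
compound 2 `O=C1[C@H](Cc2n[nH]c3ccccc23)C(=O)N(c2ccccc2)C=CN1CC(=O)N1CCCCc2ccccc21`, 61.7 nM in this assay

Among the compounds with values here, of the two numbers measured in this assay, compound 1 holds the higher one; the only other measurement lies a large step away, a 25-fold lower number from compound 1 to compound 2 (1.40 log units; beyond the scatter), a step that accompanies exchange of the group on the carbonyl carbon. Compound 3 `COc1ccc(N(C(=O)CN2C=CN(c3ccccc3)C(=O)[C@H](Cc3n[nH]c4ccccc34)C2=O)C(C)C)cc1` has not yet been measured in this assay. It differs from compound 1 only in configuration: the two compounds have the same atoms and bonds and differ only in configuration as drawn: 1 of 1 stereo elements differ; a stereocentre at a saturated ring carbon is drawn S in compound 1 and R in compound 3. Within the data shown here, no measured step bears on this change, since the single step in hand alters the group on the carbonyl carbon and leaves the stereocentre untouched; it shows only that the series responds strongly to a change at that position. Inversion of the sole stereocentre in a compound already holding the higher of two numbers has no measured counterpart, so the expectation for compound 3 rests on the change alone. Compound 3 is expected to give 6000 nM in this assay, with a range of 1500 nM to 30000 nM. This estimate means a step of a 3.9-fold higher number from compound 1 to compound 3 (0.59 log units; beyond the scatter), expected to run towards a higher number, with considerable uncertainty.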

Compound 3, half-maximal effective concentration: 15.9 nM
For compound 3 the middle estimate is 380-fold (2.58 log units) above the measured one; measured number outside the range, below it.
By their numbers in this assay, from the lowest: compound 3; then compound 2; then compound 1.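

The stereocentre at the saturated ring carbon proves to be a position of large consequence in this assay and not a minor detail of the series: with the group on the carbonyl carbon unchanged, going from S to R brings a 97-fold lower number from compound 1 to compound 3 (1.99 log units; beyond the scatter) and takes the series from the higher end of its numbers to the lower. The earlier step showed only that the series answers to an exchange of the group on the carbonyl carbon, whereas this step shows a large movement with no atom entering or leaving. The change can be set down to configuration alone because nothing else separates the pair: the fact that compounds 1 and 3 differ only in the configuration as drawn.

The compounds shown leave open whether the same inversion would bring a step of like size with the group of compound 2 on the carbonyl carbon, as compound 1 and compound 3 are the only pair here that differ in configuration. They also leave open how the R form would respond to a carboxylic acid or a primary amine in the group on that carbonyl carbon.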